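From cyclopentyl to isopropyl on an aromatic nitrogen

The compounds below may be only part of what the source reports. "The series", "measured", "known", "first", "only" and "open" are said of these compounds alone.

Within the data shown here, in a functional assay on HCC827 cells (Homo sapiens) for antiproliferative activity, read by MTT assay, with a stated time of 72 h (on this read-out lower numbers stand for stronger inhibition and higher numbers for weaker inhibition), compound 3 `CN1CCN(c2ccc(Nc3ncc4nc([S+]([O-])c5ccccc5)n(C5CCCC5)c4n3)cc2)CC1` gives 64.7 nM, the lowest of the three numbers so far. Compound 1 `CC(C)n1c(Sc2ccccc2)nc2cnc(Nc3ccc(N4CCN(C)CC4)cc3)nc21` gives 290 nM and compound 2 `CN1CCN(c2ccc(Nc3ncc4nc([S+]([O-])c5ccccc5)n(CC5CC5)c4n3)cc2)CC1` gives 838 nM, both higher by more than the scatter.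

The next comparison is compound 4 `CC(C)n1c([S+]([O-])c2ccccc2)nc2cnc(Nc3ccc(N4CCN(C)CC4)cc3)nc21`, which differs from compound 3 as follows: isopropyl in place of cyclopentyl on an aromatic nitrogen. In short, isopropyl stands in place of cyclopentyl on an aromatic nitrogen.

Among the measured compounds shown here, one measured step bears directly on this change: a 13-fold lower number from compound 2 to compound 3 (1.11 log units; beyond the scatter). This large step comes from cyclopentyl in place of cyclopropylmethyl on the same aromatic nitrogen, so the group at this place can matter greatly in this assay. That step does not involve isopropyl, however, and its size carries over only loosely. Compound 1 also has isopropyl on an aromatic nitrogen and gives 290 nM, but it differs from compound 4 elsewhere, so it serves only as a rough guide.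

With cyclopentyl leaving the compound that holds the lowest number, a moderate move to a higher number is expected, smaller than the measured step. The expected change is a 2.6-fold higher number from compound 3 to compound 4 (0.42 log units; beyond the scatter). The estimate for compound 4 is 170 nM, with an expected range from 70 nM to 420 nM.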

Compound 4, half-maximal inhibitory concentration: 215 nM
Compound 4: middle estimate off by 1.3-fold (0.10 log units), on the low side, and the stated range covers the measured number.
By their numbers in this assay, from the lowest: compound 3; then compounds 4 and 1 (each within the scatter of the next); then compound 2.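

In this assay the step of a 3.3-fold higher number from compound 3 to compound 4 (0.52 log units; beyond the scatter) and the step of a 3.9-fold lower number from compound 2 to compound 4 (0.59 log units; beyond the scatter) set isopropyl apart from both cyclopentyl and cyclopropylmethyl on this aromatic nitrogen, with isopropyl, which has no ring, giving a number between those of the two ring-bearing groups, so the presence of a ring alone does not sort these three compounds. With isopropyl held on the nitrogen, the other change, on the aromatic carbon, gives a 1.3-fold lower number from compound 1 to compound 4 (0.13 log units; within the scatter) and so does not separate the group of 8 heavy atoms from the group of 7 heavy atoms in this pair. No independent measurement on these compounds bears on why the groups on the nitrogen rank in this way.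

From the compounds shown here alone, whether the order extends to a cyclobutyl or cyclohexyl ring, or to an open chain carrying a hydroxyl or an amine, remains open at this nitrogen. Also open, going by these compounds, is whether the change on the aromatic carbon stays as small when cyclopentyl, rather than isopropyl, sits on the nitrogen.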